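The compounds below may be only part of what the source reports. "The series", "measured", "known", "first", "only" and "open" are said of these compounds alone.

Of the compounds shown here, two built on one shared core have been tested in an assay on isolated protein for binding affinity to 5-hydroxytryptamine receptor 6 (Homo sapiens); on this read-out higher numbers stand for weaker inhibition and lower numbers for stronger inhibition. Compound 1 `COc1cccc(-c2n[nH]cc2N2CCCNCC2)c1` returns only a limit of the assay, > 10000 nM, and no number. Compound 2 `COc1ccccc1-c1n[nH]cc1N1CCNCC1` likewise returns only a limit, > 10000 nM. Going by the values given here, compound 2 therefore stands at the edge of what this assay can report, and the one other value shown sits at that same edge, as the limit of > 10000 nM in this assay, at which 2 of the 2 values shown sit, records. The next compound, compound 3 `Clc1ccccc1-c1n[nH]cc1N1CCNCC1`, is compound 2 with a single change: chloro in place of methoxy on an aromatic carbon. Among the compounds with values here, no measured pair differs in only one place, so no step can be read off from the numbers. Compound 3 is expected to remain near the limit, at an estimated 8000 nM with a range from 1500 nM to 30000 nM. The expected step of an at least 1.2-fold lower number from compound 2 to compound 3 (0.09 log units; that floor lies within the scatter) is small, not clearly beyond the scatter in either direction, and a limit again seems more likely than a number.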

Compound 3, inhibition constant: > 10000 nM
Compound 3 was reported as a limit (the forecaster's own chance of this, stated with the estimate: 60%); middle value at least 1.2-fold (0.09 log units) away from the limit.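

Chloro in place of methoxy leads from compound 2 to compound 3, but no step can be read, as both compounds stop at a limit: the limit of > 10000 nM in this assay, at which 3 of the 3 values shown sit.

The compounds shown leave open whether methoxy and chloro differ at all in this assay and what change to the shared core would give a measurable number.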